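The source may report more compounds than this note shows. Statements on the series, on what has been measured and on what is new or still open speak of the compounds shown alone.

Compound 1, `Cc1ccc2c(NCc3ccc(NC(=O)C4CCN(CC5CCNCC5)CC4)cc3)nc(N(C)C)nc2c1`: in a functional assay on SV5A8 cells (Homo sapiens) for cytotoxicity (a lower number here means a stronger inhibitor, a higher number a weaker inhibitor), compound 1 gives > 8070 nM, which is a limit of the assay.
Compound 2, `Cc1ccc2c(NCc3ccc(NC(=O)C4CCN(Cc5cccc(F)c5)CC4)cc3)nc(N(C)C)nc2c1`: in this assay compound 2 gives > 4170 nM, again a limit.
Compound 3, `Cc1ccc2c(NCc3ccc(NC(=O)C4CCN(Cc5ccccc5F)CC4)cc3)nc(N(C)C)nc2c1`: in this assay compound 3 gives > 6670 nM, also a limit.

Compound 3 therefore stands nowhere definite: its own number is only a limit, and the two further values shown beside it are limits as well, as the limit of > 8070 nM in this assay, at which 1 of the 3 values shown sits, the limit of > 4170 nM in this assay, at which 1 of the 3 values shown sits, and the limit of > 6670 nM in this assay, at which 1 of the 3 values shown sits, record. The steps among the three measured compounds cannot be read: a step that the two limits leave unreadable from compound 1 to compound 3, a step that the two limits leave unreadable from compound 2 to compound 3 and a step that the two limits leave unreadable from compound 1 to compound 2 all fall between two limits.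

Compound 4, `COc1ccc(CN2CCC(C(=O)Nc3ccc(CNc4nc(N(C)C)nc5cc(C)ccc45)cc3)CC2)cc1`, differs from compound 3 by 4-methoxyphenyl in place of 2-fluorophenyl on a saturated chain carbon bound to an amine nitrogen in a ring. For the measured compounds named here, none of the measured steps gives a readable size, so nothing bears on this change with a direction or a magnitude; the only pattern the numbers show is that every variation so far at this place has stayed at a limit. Compound 4 is therefore expected to sit at a limit as well, with an estimated value of 10000 nM and a range from 3000 nM to 30000 nM. The expected step is a step that the limit leaves unreadable from compound 3 to compound 4, which is estimated to stay within the scatter.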

Compound 4, half-maximal inhibitory concentration: > 6180 nM
Compound 4 ended at the assay's limit (the forecaster's own chance of this, stated with the estimate: 75%); the middle value lies beyond the limit too.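

Compound 4, like compound 1, compound 2 and compound 3, gives only a limit in this assay, so the steps from those three compounds to compound 4 cannot be read. The compounds shown leave open whether changing the group at this place alters cytotoxicity at all.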